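The compounds below may be only part of what the source reports. "The series", "measured", "known", "first", "only" and "open" are said of these compounds alone.

Compound 3 `COc1ccc(C2=C(c3cc(OC)c(OC)c(OC)c3)C(=O)CC2O)cc1` carries a free hydroxyl on its central ring. In an ADME assay on DU-145 cells (Homo sapiens) for cytotoxicity, read by MTT assay, with a stated time of 72 h (on this read-out higher numbers stand for weaker inhibition and lower numbers for stronger inhibition), compound 3 gives 18.7 ug/mL. Compound 1 `COc1ccc(C2=C(c3cc(OC)c(OC)c(OC)c3)C(=O)CC2O[SiH2]C(C)(C)C)cc1` differs from it at that hydroxyl: a group of 5 heavy atoms (4 carbon, 1 silicon; no ring) in place of a hydrogen atom, on an oxygen on a saturated carbon In this assay compound 1 gives > 100 ug/mL, which is a limit of the assay rather than a number. That change produced an at least 5.3-fold higher number from compound 3 to compound 1 (0.72 log units; beyond the scatter), and its size is only known as a bound because of the limit of > 100 ug/mL in this assay, at which 2 of the 3 values shown sit.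

Compound 2 `COc1ccc(C2=C(c3cc(OC)c(OC)c(OC)c3)CC(O)C2=O)cc1[N+](=O)[O-]` has another core; the difference between the two cores is not broken down here. In this assay compound 2 gives > 100 ug/mL, a limit of the assay. Compound 4 `COc1ccc(C2=C(c3cc(OC)c(OC)c(OC)c3)CC(O[SiH2]C(C)(C)C)C2=O)cc1[N+](=O)[O-]` makes the same change to compound 2: a group of 5 heavy atoms (4 carbon, 1 silicon; no ring) in place of a hydrogen atom, on an oxygen on a saturated carbon Since compound 2 already sits at the limit and the same change weakened compound 1, compound 4 is expected to stay at the limit, an estimated step that the limit leaves unreadable from compound 2 to compound 4. Compound 4 is expected near 150 ug/mL, between 60 ug/mL and 400 ug/mL.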

Compound 4, half-maximal inhibitory concentration: > 100 ug/mL
Compound 4 gave a limit, no number; the forecaster's own chance of this, stated with the estimate: 85%; the middle value does not contradict the limit.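

No step can be read from compound 2 to compound 4, because both give a limit rather than a number: the limit of > 100 ug/mL in this assay, at which 3 of the 4 values shown sit.

The compounds shown leave open whether the silicon-containing group changes activity at all on the core of compound 2.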